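Methylating a Hydroxy Group on a Quinazolinone Hydrazone Series

The source may hold more compounds than are shown below. What is called first, only, known or untested is meant among the compounds shown, and "the series" means these compounds.

The series is a set of hydrazones carrying a trimethoxy- or hydroxylated benzylidene head. Compound 1 `COc1cc(/C=N/NC(=O)CCCc2nc3ccccc3c(=O)[nH]2)cc(OC)c1OC` gives 106000000 nM in a physicochemical assay, read by spectrophotometry, with a stated time of 30 min; a higher number here means a weaker inhibitor, a lower number a stronger inhibitor. Compound 2 `COc1cc(/C=N/NC(=O)CCCc2nc3ccccc3c(=O)[nH]2)cc(OC)c1O` gives 97000000 nM in this assay, and compound 3 `O=C(CCc1nc2ccccc2c(=O)[nH]1)N/N=C/c1cc(O)c(O)c(O)c1` gives 81000000 nM. The three numbers sit within the usual scatter of one another, so no order can be read among them. Compound 2 and compound 1 differ by one change, (methyl in place of hydrogen on an oxygen on an aromatic ring), and that step, a 1.1-fold higher number from compound 2 to compound 1 (0.04 log units; within the scatter), left the number essentially unchanged. Compound 4 `COc1cc(/C=N/NC(=O)CCc2nc3ccccc3c(=O)[nH]2)cc(O)c1O` has not yet been measured in this assay. It stands to compound 3 as compound 1 stands to compound 2: the difference is methyl in place of hydrogen on an oxygen on an aromatic ring, the same change at the same kind of place. The difference between the core of compound 3 and the core of compound 2 is not broken down here. Because the earlier step of a 1.1-fold higher number from compound 2 to compound 1 (0.04 log units; within the scatter) was within the scatter, compound 4 is expected to move from compound 3 by about a 1.1-fold higher number from compound 3 to compound 4 (0.05 log units; within the scatter). Compound 4 is therefore estimated at 90000000 nM, most likely between 45000000 nM and 180000000 nM.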

Compound 4, half-maximal inhibitory concentration: 104000000 nM
Compound 4: the middle estimate sits 1.2-fold (0.06 log units) below what was measured; the measured number falls inside the stated range.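

In this assay, the hydroxy to methoxy change gives a 1.3-fold higher number from compound 3 to compound 4 (0.11 log units; within the scatter) on one core and a 1.1-fold higher number from compound 2 to compound 1 (0.04 log units; within the scatter) on the other, so both steps lie within the scatter and neither core shows a measurable response to the change. This shows that, on these two cores, putting methyl in place of hydrogen on an oxygen on an aromatic ring leaves the number essentially unchanged; it does not show that a real effect of a given size carries from one core to the other, as two steps within the scatter cannot establish that. Nothing measured here explains this result.

The compounds shown leave open whether the hydroxy group can be replaced by an amine or a carboxylic acid with an equally small step. They also leave open whether replacing that hydrogen with an ethyl group would stay within the scatter on either core.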